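A few compounds are considered here, and "the series" means these few. Any claim that something is new, unique, unknown or untested is made for them only; others in the source may bear on it.

Measured in an ADME assay on MT4 cells (Homo sapiens) for cytotoxicity, read by MTT assay, with a stated time of 5 days; a lower number here means that less compound is tolerated, a higher number that more compound is tolerated:
compound 1, `O=C1N(Cc2ccccc2Br)c2cccn2S(=O)(=O)N1Cc1cccc(F)c1`: > 269000 nM, a limit of the assay rather than a number
compound 2, `O=C1N(Cc2ccccc2Br)c2cccn2S(=O)(=O)N1Cc1ccccc1`: 226000 nM

Within the data shown here, compound 2 gives the only number in this assay; the one other value is a limit. Among the measured compounds shown here, the single measured step is an at least 1.1-fold lower number from compound 1 to compound 2 (0.07 log units; that floor lies within the scatter), hydrogen in place of fluoro on an aromatic carbon, and its floor sits within the scatter, so it shows no change in tolerated concentration.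

Compound 3, `O=C1N(Cc2ccccc2)c2cccn2S(=O)(=O)N1Cc1ccccc1`, differs from compound 2 by hydrogen in place of bromo on an aromatic carbon. For the measured compounds named here, no measured step removes a bromo; the only step that bears on the change, an at least 1.1-fold lower number from compound 1 to compound 2 (0.07 log units; that floor lies within the scatter), is another halogen-to-hydrogen exchange on a benzyl ring and was within the scatter. The expected step in this assay is therefore none beyond the scatter: a 1.1-fold higher number from compound 2 to compound 3 (0.03 log units; within the scatter). Compound 3 is estimated at 240000 nM, range 110000 nM to 500000 nM. The evidence the limit of > 269000 nM in this assay, at which 1 of the 2 values shown sits, shows that a limit instead of a number is also a likely outcome.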

Compound 3, half-maximal cytotoxic concentration: 196000 nM
Estimate against measurement, compound 3: 1.2-fold (0.09 log units) above; measured number inside the range.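

In this assay, among these compounds, the exchange of 2-bromobenzyl for benzyl gives a 1.2-fold lower number from compound 2 to compound 3 (0.06 log units; within the scatter), the only step here that joins two numbers rather than a number and a limit. Among the compounds shown here, with the bromo gone from its place ortho to a large group, the two numbers stay within the scatter of each other, and compound 3 carries neither halogen found in the earlier compounds. The value of compound 1 remains a limit, the only one among the three values: the limit of > 269000 nM in this assay, at which 1 of the 3 values shown sits.

Open, as far as these compounds go, is whether an amine or a carboxylic acid on this aromatic ring would move the number in this assay beyond the scatter. Also open, from the compounds shown here alone, is whether a longer chain in place of either benzyl group on the shared core would do so.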